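This account rests on a few compounds, and the source may have more. Where it says the series, first, only, none or still open, it means among the compounds named here.

The measured compounds are: compound 1 `O=C1C=C(NCc2ccccc2)C(=O)c2c1nc1n2[C@H]2OC[C@@H](O)[C@H]2OC1`, compound 2 `COc1ccccc1NC1=CC(=O)c2c(nc3n2[C@H]2OC[C@@H](O)[C@H]2OC3)C1=O` and compound 3 `O=C1C(N2CCCCC2)=CC(=O)c2c1nc1n2[C@H]2OC[C@@H](O)[C@H]2OC1`.

In a functional assay on MCF7 cells (Homo sapiens) for inhibition, read by sulforhodamine B assay (on this read-out lower numbers stand for stronger inhibition and higher numbers for weaker inhibition), compound 1 gives only a limit, > 8000 nM. Compound 2 gives 6580 nM. Compound 3 likewise gives only a limit, > 8000 nM. Among the compounds with values here, compound 1 thus sits at the limit of > 8000 nM in this assay, at which 2 of the 3 values shown sit, and the one measured number belongs to compound 2. Within the data shown here, the only single-change step recorded, from compound 2 to compound 3, was an at least 1.2-fold higher number from compound 2 to compound 3 (0.08 log units; that floor lies within the scatter). The unmeasured compound 4 `O=C1C=C(Nc2cccc(Cl)c2)C(=O)c2c1nc1n2[C@H]2OC[C@@H](O)[C@H]2OC1` differs from compound 1 by 3-chlorophenyl in place of benzyl on an amine nitrogen. Among the measured compounds shown here, no measured step covers this change, yet compound 2, the only other arylamino compound, is the one that gave a number. Compound 4 is therefore expected near that value, with the step of an at least 1.3-fold lower number from compound 1 to compound 4 (0.12 log units; that floor lies within the scatter) counted from a limit. Compound 4 is estimated at 6000 nM, between 2000 nM and 20000 nM.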

Compound 4, half-maximal inhibitory concentration: 4720 nM
Compound 4: the middle estimate sits 1.3-fold (0.10 log units) above what was measured; measured number inside the range.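

In this assay, the change on the amine nitrogen gives an at least 1.6-fold lower number from compound 1 to compound 4 (0.22 log units; that floor lies within the scatter), which is only a floor and does not by itself establish a real difference. What compound 4 adds is a second measured number for a compound with an aryl group directly on that nitrogen, alongside compound 2. Compound 1 and compound 3 remain at a limit, so the true size of the step cannot be read: the limit of > 8000 nM in this assay, at which 2 of the 4 values shown sit.

The compounds shown leave open whether the chlorine contributes, as an unsubstituted phenyl on the same nitrogen would show. They also leave open how a longer chain such as phenethyl would read.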